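Quinoline series: swapping the chloro-ynyl selenide for a hydroxy-ynyl sulfide

This account rests on a few compounds, and the source may have more. Where it says the series, first, only, none or still open, it means among the compounds named here.

Measured so far in a functional assay on SW707 cells (Homo sapiens) for antiproliferative activity, with a stated time of 72 h; on this read-out higher numbers stand for weaker inhibition and lower numbers for stronger inhibition:
- compound 1 `C#CCSc1cnc2ccccc2c1[Se]CC#CCCl` gives 3.2 ug/mL
- compound 2 `CSc1cnc2ccccc2c1[Se]CC#CCCl` gives 3.2 ug/mL
- compound 3 `OCC#CCSc1cnc2ccccc2c1[Se]CC#CCCl` gives 3.3 ug/mL

Compound 2 stands level with compound 1 at the digits shown, the two together the lowest of the three numbers; compound 3 sits nearest above it, a 1.0-fold higher number from compound 2 to compound 3 (0.01 log units; within the scatter). The steps of no change at the digits printed from compound 1 to compound 2 (within the scatter) and a 1.0-fold higher number from compound 1 to compound 3 (0.01 log units; within the scatter) are likewise flat, so every change so far on the sulfur-bound chain left the read-out untouched.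

Compound 4 `CSc1cnc2ccccc2c1SCC#CCO` differs from compound 2 elsewhere: a group of 6 heavy atoms (4 carbon, 1 oxygen, 1 sulfur; no ring) in place of a group of 6 heavy atoms (4 carbon, 1 chlorine, 1 selenium; no ring), on an aromatic carbon. Among the compounds with values here, no measured step touches this position, so the flat steps among compounds 1, 2 and 3 cannot be carried over directly; they only show that the shared core has tolerated side-chain variation without moving the number. With nothing to indicate a direction, compound 4 is expected to land near compound 2, the estimated step being a 1.6-fold higher number from compound 2 to compound 4 (0.19 log units; within the scatter), with a wider range than usual because of the unexplored position. The estimate for compound 4 is 5 ug/mL, between 1.8 ug/mL and 15 ug/mL.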

Compound 4, concentration for 50% inhibition: 34.9 ug/mL
Compound 4: the middle estimate sits 7.0-fold (0.84 log units) below what was measured; the measured number lies above the stated range.
By their numbers in this assay, from the lowest: compounds 1, 2 and 3 (each within the scatter of the next); then compound 4.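

Unlike the sulfur-bound chain, where every step stayed within the scatter, the group on this aromatic carbon does matter in this assay, with the exchange giving an 11-fold higher number from compound 2 to compound 4 (1.04 log units; beyond the scatter) and a step beyond the scatter. The exchange replaces chlorine and selenium with oxygen and sulfur in one move, so the step belongs to the whole group and not to either atom alone. Nothing available explains the size of this step.

The compounds shown leave open whether the selenium-to-sulfur or the chlorine-to-oxygen part carries the step, and a chain keeping selenium with the oxygen end, or sulfur with the chlorine end, would separate the two. Also open, as far as these compounds go, is how an amine or a carboxylic acid at the chain end would read, and whether the step holds with the other sulfur-bound chains.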